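The source may report more compounds than this note shows. Statements on the series, on what has been measured and on what is new or still open speak of the compounds shown alone.

Measured in a functional assay on MCF7 cells (Homo sapiens) for antiproliferative activity, read by MTT assay, with a stated time of 48 h; a higher number here means a weaker inhibitor, a lower number a stronger inhibitor:
- compound 1 `Fc1ccc(-c2nn(-c3ccccc3)cc2-c2nc3cc(Cl)ccc3[nH]2)cc1` gives 2230 nM
- compound 2 `Fc1ccc(-c2nn(-c3ccccc3)cc2-c2nc3cc(C(F)(F)F)ccc3[nH]2)cc1` gives 2130 nM
- compound 3 `Fc1ccc(-c2nn(-c3ccccc3)cc2-c2nc3cc(Cl)c(Cl)cc3[nH]2)cc1` gives 6930 nM

Compound 3 carries the highest number of the three, and its values stand clear of those of compound 1 and compound 2 by more than the scatter. The next analogue, compound 4 `COc1ccc(-c2nn(-c3ccccc3)cc2-c2nc3cc(Cl)c(Cl)cc3[nH]2)cc1`, differs from it by methoxy in place of fluoro on an aromatic carbon in the change of methoxy in place of fluoro on an aromatic carbon, that is, 4-fluorophenyl to 4-methoxyphenyl.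

For the measured compounds named here, no measured step touches this place, since all three measured compounds keep the fluoro. The nearest evidence comes from elsewhere on the core: a 3.1-fold higher number from compound 1 to compound 3 (0.49 log units; beyond the scatter) with chloro in place of hydrogen, and a 1.0-fold lower number from compound 1 to compound 2 (0.02 log units; within the scatter) with trifluoromethyl in place of chloro. These steps give no direction for the new change, so no shift beyond the scatter is expected, and the estimate stays close to compound 3. The expected change is a 1.3-fold lower number from compound 3 to compound 4 (0.10 log units; within the scatter) in this estimate. For compound 4 the estimated value is 5500 nM with an expected range from 1800 nM to 16000 nM in this assay.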

Compound 4, half-maximal inhibitory concentration: 13200 nM
Compound 4: middle estimate off by 2.4-fold (0.38 log units), on the low side; the measured number falls inside the stated range.
By their numbers in this assay, from the lowest: compounds 2 and 1 (each within the scatter of the next); then compounds 3 and 4 (each within the scatter of the next).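

For the compounds shown here, the change from 4-fluorophenyl to 4-methoxyphenyl gives a 1.9-fold higher number from compound 3 to compound 4 (0.28 log units; within the scatter) in this assay, the first reading at this place, taken on the compound with two chloro groups. This place therefore takes methoxy, with its additional heavy atom and its hydrogen-bond acceptor, without a shift beyond the scatter. No measurement at hand accounts for the size of this step.

Going by these compounds alone, whether the same change reads alike with the single chloro of compound 1 or the trifluoromethyl of compound 2 stays open. Also open, from the compounds shown here alone, is how this place responds when an amine, a carboxylic acid or a longer chain such as ethoxy stands in place of fluoro or methoxy.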